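The compounds below may be only part of what the source reports. "The series", "measured", "known", "first", "only" and "open" are said of these compounds alone.

Measured in a functional assay on Ramos cells (Homo sapiens) for antiproliferative activity, read by CCK-8 assay, with a stated time of 72 h, tested at 40 uM; on this read-out lower numbers stand for less inhibition and higher numbers for more inhibition at the one concentration tested (going by the name of the read-out):
- compound 1 `CCOC(=O)c1sc(-c2cccc(NC(=O)c3ccc(F)cc3)c2)nc1Nc1ccc(N2CCN(C)CC2)cc1`: 3.53%
- compound 2 `CCOC(=O)c1sc(-c2cccc(NC(=O)c3ccccc3)c2)nc1Nc1ccc(N2CCN(C)CC2)cc1`: 77.1%
- compound 3 `CCOC(=O)c1sc(-c2cccc(NC(=O)c3ccc(C#N)cc3)c2)nc1Nc1ccc(N2CCN(C)CC2)cc1`: 97.5%

Compound 2 stands second highest of the three in this assay: compound 3 lies above it by a number 20.4 percentage points higher from compound 2 to compound 3 (beyond the scatter), while the step of a number 73.6 percentage points higher from compound 1 to compound 2 (beyond the scatter) leaves compound 1 furthest away. Compound 4 `CCOC(=O)c1sc(-c2cccc(NC(=O)[C@H]3CC[C@H](C)CC3)c2)nc1Nc1ccc(N2CCN(C)CC2)cc1` differs from compound 2 by 4-methylcyclohexyl in place of phenyl on a carbonyl carbon. For the measured compounds named here, no measured step touches the group on the carbonyl carbon; all three, a number 73.6 percentage points higher from compound 1 to compound 2 (beyond the scatter), a number 94 percentage points higher from compound 1 to compound 3 (beyond the scatter) and a number 20.4 percentage points higher from compound 2 to compound 3 (beyond the scatter), vary only a substituent on the aromatic ring, and they show that this region moves the read-out strongly, but give no direction for a change of the ring itself. The expected step is a number 27.1 percentage points lower from compound 2 to compound 4 (beyond the scatter), with low confidence. Compound 4 is estimated at 50%, within 8% to 92%.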

Compound 4, a percentage reported as inhibition, at one concentration (the size of the read-out at that concentration, not a potency): 19.9%
For compound 4 the middle estimate is 30.1 percentage points above the measured one, within the range that was stated.
By their numbers in this assay, from the lowest: compound 1; then compound 4; then compound 2; then compound 3.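

In this assay, changing the ring itself on the carbonyl carbon to 4-methylcyclohexyl gives a number 57.2 percentage points lower from compound 2 to compound 4 (beyond the scatter) and a number 77.6 percentage points lower from compound 3 to compound 4 (beyond the scatter) for the phenyl and 4-cyanophenyl cases, so an aromatic ring at this position is not interchangeable with this non-aromatic one. Compound 1 goes against that direction, with a number 16.4 percentage points higher from compound 1 to compound 4 (beyond the scatter) from its 4-fluorophenyl group, so the sign of the change depends on the ring being replaced. No measurement here accounts for these steps.

Still open, going by these compounds, is whether the drop follows the loss of aromaticity or the added methyl, which unsubstituted cyclohexyl would separate. A pyridine ring or a piperidine ring on the carbonyl carbon also remains to be placed against compound 2.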